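From Compound 1 to Compound 4: a Benzyl Ring Swap

The source may hold more compounds than are shown below. What is called first, only, known or untested is meant among the compounds shown, and "the series" means these compounds.

Of the compounds shown here, three have been measured in a functional assay on HeLa cells (Homo sapiens) for cytotoxicity, read by MTT assay, with a stated time of 72 h; on this read-out lower numbers stand for stronger inhibition and higher numbers for weaker inhibition. Compound 1 `Cc1cc(S(=O)(=O)/N=C(\N)n2nccc2-c2ccccc2)c(SCc2ccc(Cl)cc2)cc1Cl` gives 3000 nM. Compound 2 `Cc1cc(-c2ccccc2)n(/C(N)=N/S(=O)(=O)c2cc(C)c(Cl)cc2SCc2ccc(C(F)(F)F)cc2)n1` gives 19000 nM. Compound 3 `Cc1cc(-c2ccccc2)n(/C(N)=N/S(=O)(=O)c2cc(C)c(Cl)cc2SCc2cccc3ccccc23)n1` gives 3000 nM.

On these numbers compound 1 stands level with compound 3 at the digits shown, and the two of them share the lowest value of the three; compound 2 is the furthest from compound 1, with the highest number of the set. Going by the values given here, the only step measured between two compounds that differ in one place is a 6.3-fold lower number from compound 2 to compound 3 (0.80 log units; beyond the scatter), which shows that the group carried on the saturated chain carbon bound to a sulfur can shift this read-out by a modest amount beyond the scatter.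

Compound 4 `Cc1cc(S(=O)(=O)/N=C(\N)n2nccc2-c2ccccc2)c(SCc2ccccc2C)cc1Cl` differs from compound 1 at that same position: 2-methylphenyl in place of 4-chlorophenyl on a saturated chain carbon bound to a sulfur. Among the compounds with values here, no measured pair shows what exchanging a 4-chlorophenyl for a 2-methylphenyl does here, and the one step at this place involved other groups. The expectation therefore rests on a single precedent of modest size, and the estimated step is a 1.3-fold higher number from compound 1 to compound 4 (0.12 log units; within the scatter), with a wide range either way. Compound 4 is expected to give about 4000 nM in this assay, between 1500 nM and 12000 nM.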

Compound 4, half-maximal inhibitory concentration: 17000 nM
The estimate for compound 4 lay 4.3-fold (0.63 log units) below the measured number; measured number above the stated range.
By their numbers in this assay, from the lowest: compounds 1 and 3 (each within the scatter of the next); then compounds 4 and 2 (each within the scatter of the next).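

In this assay, the exchange of 4-chlorophenyl for 2-methylphenyl on the saturated chain carbon bound to a sulfur gives a 5.7-fold higher number from compound 1 to compound 4 (0.75 log units; beyond the scatter) and so shows that this place also responds on the core of compound 1, whereas the earlier step at this place, a 6.3-fold lower number from compound 2 to compound 3 (0.80 log units; beyond the scatter), was read on the different core of compounds 2 and 3. The result also shows that the number can move beyond the scatter even where the two groups have the same heavy-atom count, the same single six-membered aromatic ring of carbon only, and the same count of hydrogen-bond donors and acceptors, so these shared counts do not settle the outcome at this place. Nothing available here bears on why the number rose with this exchange.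

The single exchange removes the chlorine and brings in the methyl at once, so the compounds shown leave open how much of the step belongs to each of those two changes, and an unsubstituted phenyl at this place would be needed to separate them. They also leave open whether naphthalen-1-yl, or a group of another kind such as an amine or a longer chain, would be tolerated here on the core of compound 1.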